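The source may report more compounds than this note shows. Statements on the series, on what has been measured and on what is new or still open speak of the compounds shown alone.

Three compounds share one core and differ only in the group on a saturated chain carbon bound to an aromatic nitrogen. Compound 1 `Nc1nc(O)c2c(n1)n(C1OC(CO)[C@@H](O)[C@H]1O)c(=O)n2CC(O)CO` carries a 1,2-dihydroxyethyl group there, compound 2 `CN(C)CCCn1c(=O)n(C2OC(CO)[C@@H](O)[C@H]2O)c2nc(N)nc(O)c21` a 2-(dimethylamino)ethyl group, and compound 3 `Cn1c(=O)n(C2OC(CO)[C@@H](O)[C@H]2O)c2nc(N)nc(O)c21` only a hydrogen. In a functional assay on the whole organism (B cells) with Mus musculus as the target (a higher number here means a larger maximal response, a lower number a smaller maximal response), compound 1 gives 136%, compound 2 gives 83%, and compound 3 gives 99%. Compound 3 thus stands second highest of the three: a number 37 percentage points lower from compound 1 to compound 3 (beyond the scatter), while a number 16 percentage points higher from compound 2 to compound 3 (beyond the scatter).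

Compound 4 `CCCCn1c(=O)n(C2OC(CO)[C@@H](O)[C@H]2O)c2nc(N)nc(O)c21` is the next step from compound 3, with propyl in place of hydrogen on a saturated chain carbon bound to an aromatic nitrogen. Within the data shown here, no measured pair shows exactly this change. The closest is the step of a number 16 percentage points higher from compound 2 to compound 3 (beyond the scatter), where a chain with a nitrogen at that carbon went with a modestly lower maximal response than the bare hydrogen; the step of a number 53 percentage points lower from compound 1 to compound 2 (beyond the scatter) shows that the kind of chain matters greatly. A propyl chain carries neither the hydroxyls of compound 1 nor the amino group of compound 2, so a modest lowering or no step beyond the scatter is expected. Compound 4 is therefore estimated at 90%, within 70% to 112%, an expected step of a number 9 percentage points lower from compound 3 to compound 4 (within the scatter).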

Compound 4, largest response reached (reported as maximal response), in percent of the reference or control that the assay uses: 86%
For compound 4 the middle estimate is 4 percentage points above the measured one, within the range that was stated.
By their numbers in this assay, from the lowest: compounds 2 and 4 (each within the scatter of the next); then compound 3; then compound 1.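

In this assay a plain propyl chain on this saturated chain carbon is enough to lower the maximal response compared with the bare hydrogen (a number 13 percentage points lower from compound 3 to compound 4 (beyond the scatter)), so a chain carrying neither hydroxyl groups nor an amino group does not leave the response where it was. Changing the end of the chain from dimethylamino to methyl gives no step that can be told from the scatter (a number 3 percentage points higher from compound 2 to compound 4 (within the scatter)), which means the lower number of compound 2 does not depend on its amino group, while the large gap to the diol chain (a number 50 percentage points lower from compound 1 to compound 4 (beyond the scatter)) leaves compound 1 as the only one of these compounds above the bare hydrogen. Nothing measured here explains why these chains differ in this way.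

As far as these compounds go, it remains open whether a longer chain such as hexyl would lower the response further or whether it would level off. Also open, from the compounds shown here alone, is whether a single hydroxyl group on the propyl chain would be enough to raise the response, and what a carboxylic acid at the end of the chain would do.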